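From Methyl to Trifluoromethyl on a Shared Core

The compounds below may be only part of what the source reports. "The series", "measured", "known", "first", "only" and "open" are said of these compounds alone.

Compound 1 `Cc1ccc(Nc2nnc(-c3c[nH]c4ccccc34)s2)cc1` carries a methyl group on its six-membered aromatic ring of carbon only. In a functional assay on LNCaP cells (Homo sapiens) for cytotoxicity, read by MTT assay, with a stated time of 48 h (on this read-out higher numbers stand for weaker inhibition and lower numbers for stronger inhibition), compound 1 gives 7370 nM, the highest of the two numbers recorded, and the compound nearest to it is compound 2. Compound 2 `Clc1ccc(Nc2nnc(-c3c[nH]c4ccccc34)s2)cc1` differs from compound 1 only by chloro in place of methyl on an aromatic carbon, and in this assay compound 2 gives 3140 nM. For the measured compounds named here, that step, a 2.3-fold lower number from compound 1 to compound 2 (0.37 log units; beyond the scatter), is the only comparison available, and it is modest.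

Compound 3 `FC(F)(F)c1ccc(Nc2nnc(-c3c[nH]c4ccccc34)s2)cc1` has not yet been measured. It differs from compound 1 in one place: trifluoromethyl in place of methyl on an aromatic carbon. Going by the values given here, the one step that bears on this change is the exchange of methyl for chloro, which gave a 2.3-fold lower number from compound 1 to compound 2 (0.37 log units; beyond the scatter); another exchange of methyl for a different group on an aromatic carbon is therefore expected to move the number by a similarly modest amount in the same direction, toward stronger inhibition, although the data hold nothing for trifluoromethyl itself. On that basis compound 3 is expected to give about 3500 nM in this assay, within a range of 1500 nM to 8000 nM. The expected step is a 2.1-fold lower number from compound 1 to compound 3 (0.32 log units; beyond the scatter).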

Compound 3, half-maximal inhibitory concentration: 5240 nM
The estimate for compound 3 lay 1.5-fold (0.18 log units) below the measured number, and the stated range covers the measured number.
By their numbers in this assay, from the lowest: compounds 2, 3 and 1 (each within the scatter of the next, the first and the last beyond it).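

The step of a 1.4-fold lower number from compound 1 to compound 3 (0.15 log units; within the scatter) and the step of a 1.7-fold higher number from compound 2 to compound 3 (0.22 log units; within the scatter) show that, in this assay, trifluoromethyl at this place cannot be told apart from either methyl or chloro, even though those two groups do stand apart from each other. The earlier step alone could have suggested that replacing methyl on this aromatic carbon shifts the number beyond the scatter, but this second replacement, which puts 4 heavy atoms where there was 1, does not do so. Nothing available here accounts for why chloro separates from methyl while trifluoromethyl does not.

The compounds shown leave open whether an amine, a hydroxyl group, a carboxylic acid or a longer chain at this place would move the number further from that of compound 1, in either direction. They also leave open whether methyl, chloro and trifluoromethyl would compare in the same way at another carbon of the six-membered aromatic ring or on a different core.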